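The source may report more compounds than this note shows. Statements on the series, on what has been measured and on what is new or still open speak of the compounds shown alone.

In an ADME assay on MT4 cells (Homo sapiens) for cytotoxicity, read by MTT assay, with a stated time of 96 h (on this read-out lower numbers stand for higher toxicity in this test and higher numbers for lower toxicity in this test), compound 1 `Cc1ccc(C2CC(c3ccccc3)=NN2c2ccc(S(N)(=O)=O)cc2)cc1` gives 40000 nM and compound 2 `Cc1ccc(C2CC(c3ccc(OCc4ccccc4)cc3)=NN2c2ccc(S(N)(=O)=O)cc2)cc1` gives 35000 nM. Among the measured compounds shown here, these are the only two numbers so far, and they lie within the scatter of each other, so compound 2 stands level with compound 1. Compound 3 `Cc1ccc(C2CC(c3ccc(Oc4ccccc4)cc3)=NN2c2ccc(S(N)(=O)=O)cc2)cc1` keeps the shared core and differs from compound 2 in one group: phenyl in place of benzyl on an oxygen on an aromatic ring. Put simply, it has phenyl in place of benzyl on an oxygen on an aromatic ring, so benzyloxy becomes phenoxy. For the measured compounds named here, one measured step bears on this, the one that introduced the benzyloxy group: a 1.1-fold lower number from compound 1 to compound 2 (0.06 log units; within the scatter), which is within the scatter. Since the whole group made no measurable difference, altering only part of it is expected to make none in this assay either. Compound 3 is estimated at 36000 nM, with an expected range from 20000 nM to 65000 nM. The expected step is a 1.0-fold higher number from compound 2 to compound 3 (0.01 log units; within the scatter), no larger than the scatter.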

Compound 3, half-maximal cytotoxic concentration: 7200 nM
For compound 3 the middle estimate is 5.0-fold (0.70 log units) above the measured one; measured number below the stated range.
By their numbers in this assay, from the lowest: compound 3; then compounds 2 and 1 (each within the scatter of the next).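

In this assay, this position on the aromatic ring proves sensitive to the exact group placed there, even though benzyloxy gave no change beyond the scatter. Swapping benzyl for phenyl on the oxygen gives a modest step towards higher toxicity in this test, with a 4.9-fold lower number from compound 2 to compound 3 (0.69 log units; beyond the scatter), and phenoxy in place of hydrogen on the aromatic carbon gives a similar result, with a 5.6-fold lower number from compound 1 to compound 3 (0.74 log units; beyond the scatter), so bulk at this position does not by itself decide the outcome. No measurement presented here explains this difference between two closely related groups.

The compounds shown leave open whether the lower number needs the phenyl ring on the oxygen, which a methoxy group would help test. They also leave open whether the oxygen matters, which a phenylamino group in place of phenoxy would probe.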